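A few compounds are considered here, and "the series" means these few. Any claim that something is new, unique, unknown or untested is made for them only; others in the source may bear on it.

Working notes on the series. Among the measured compounds shown here, in an ADME assay on a cell-free system (plasma, Rattus norvegicus) for protein binding, read by LC-MS, using equilibrium dialysis, with a stated time of 4 h (on this read-out higher numbers stand for a larger free fraction and lower numbers for a smaller free fraction), two compounds have numbers so far. Compound 1 (`Cn1cc(-c2ccc(Cc3cc(C(=O)NC4CCOCC4)nc4c3ccn4C)cn2)cn1`) gives 0.06 and compound 2 (`Cn1ccc(-c2ccc(Cc3cc(C(=O)N[C@@H]4CCCC[C@H]4O)nc4c3ccn4C)cn2)n1`) gives 0.03 on the same read-out. These two values lie within the scatter of each other, so compound 2 cannot be ranked against compound 1.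

Compound 3 (`Cn1cc(-c2ccc(Cc3cc(C(=O)N[C@@H]4CCCC[C@H]4O)nc4c3ccn4C)cn2)cn1`) has the same atoms as compound 2, joined differently. It carries 1-methyl-1H-pyrazol-4-yl in place of 1-methyl-1H-pyrazol-3-yl on an aromatic carbon of a six-membered aromatic ring with 1 nitrogen, next to the ring nitrogen and para to a large group (1-methyl-1H-pyrazol-4-yl in place of 1-methyl-1H-pyrazol-3-yl on an aromatic carbon).

For the measured compounds named here, no measured pair isolates this kind of swap, so the data offer no direct size for it. No step beyond the scatter is expected in this assay for this change, and the estimated step (a 1.3-fold higher number from compound 2 to compound 3 (0.12 log units; within the scatter)) is small. The expectation is anchored on compound 2 at 0.03 and on the narrow spread of the two numbers in hand. For compound 3 the estimated unbound fraction is 0.04 with an expected range from 0.02 to 0.08 in this assay.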

Compound 3, unbound fraction: 0.06
Compound 3: the middle estimate sits 1.5-fold (0.18 log units) below what was measured; measured number inside the range.
By their numbers in this assay, from the lowest: compounds 2, 1 and 3 (each within the scatter of the next).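

In this assay, 1-methyl-1H-pyrazol-4-yl in place of 1-methyl-1H-pyrazol-3-yl on an aromatic carbon of the six-membered aromatic ring with 1 nitrogen, next to the ring nitrogen, gives a 2.0-fold higher number from compound 2 to compound 3 (0.30 log units; within the scatter), so the series now holds a measured size for this swap and it does not exceed the scatter. Compound 3 also supplies a pair that differs only at the amide-type nitrogen: 2-hydroxycyclohexyl in place of oxan-4-yl gives no change at the digits printed from compound 1 to compound 3 (within the scatter), so with 1-methyl-1H-pyrazol-4-yl held constant the two amide groups cannot be told apart on this read-out. No available evidence bears on the reason for either step.

Going by these compounds, each change has been read in one setting only, so it remains open whether the pyrazole swap would give a similar step with oxan-4-yl on the amide, or the amide change a similar step with 1-methyl-1H-pyrazol-3-yl in place. Also open, on these data alone, is whether a carboxylic acid or an amine on the amide side, or a pyrazole lacking its methyl group, would produce a step beyond the scatter in this assay.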